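The source may hold more compounds than are shown below. What is called first, only, known or untested is meant among the compounds shown, and "the series" means these compounds.

The account follows cytotoxicity in an ADME assay on BaF3 cells (Mus musculus) for cytotoxicity (on this read-out higher numbers stand for an effect only at larger amounts of compound and lower numbers for an effect already at smaller amounts), across a small set of anilino-substituted compounds sharing one core. Compound 1 `FC(F)(F)Oc1ccc(Nc2cc(-c3ccc4[nH]ccc4c3)ncn2)cc1` gives > 10000 nM in this assay, and that figure is a limit of the assay rather than a measured number. Compound 2 `Cc1c(-c2cc(Nc3ccc(OC(F)(F)F)cc3)ncn2)cnn1-c1ccccc1` likewise gives > 10000 nM in this assay, again a limit. Compound 3 `OCCn1cc2c(Nc3ccc(OC(F)(F)F)cc3)ncnc2n1` gives > 10000 nM in this assay, also a limit. Compound 1 therefore stands nowhere in particular among the numbers shown: all three values sit at the same limit, as the limit of > 10000 nM in this assay, at which 3 of the 3 values shown sit, records, so no order among them can be drawn.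

The step to compound 4 `FC(F)(F)Oc1ccc(Nc2cc(-c3ccnc4[nH]ccc34)ncn2)cc1` consists of a group of 9 heavy atoms (7 carbon, 2 nitrogen; one five-membered aromatic ring with 1 hetero atom, one six-membered aromatic ring with 1 hetero atom) in place of a group of 9 heavy atoms (8 carbon, 1 nitrogen; one five-membered aromatic ring with 1 hetero atom, one six-membered aromatic ring of carbon only), on an aromatic carbon. Among the measured compounds shown here, no measured step between compounds with a single difference exists in this set, so the expectation rests only on the three limits. Within this assay the change from compound 1 is expected to bring a step that the limit leaves unreadable from compound 1 to compound 4, that is, nothing beyond the scatter. Compound 4 is accordingly estimated at 20000 nM, with a range from 8000 nM to 50000 nM, and most likely the assay will again report only a limit.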

Compound 4, half-maximal effective concentration: 6850 nM
Compound 4: the middle estimate sits 2.9-fold (0.47 log units) above what was measured; measured number outside the range, below it.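

Among the compounds shown here, the exchange at this position, on an aromatic carbon of the six-membered aromatic ring with 2 nitrogen, puts a six-membered aromatic ring with 1 hetero atom where the 1H-indol-5-yl group had one of carbon only, and it is the first change here to yield a number rather than a limit in this assay. The change gives an at least 1.4-fold lower number from compound 1 to compound 4 (0.16 log units; that floor lies within the scatter), so only a floor for the step is known, and that floor does not establish a real difference. Compound 4 is also the only compound shown that is not held at the limit: the limit of > 10000 nM in this assay, at which 3 of the 4 values shown sit.

On these data alone, the true size of the step remains unknown, as does whether the added ring nitrogen alone accounts for it. As far as these compounds go, how the read-out would respond to an amine or a carboxylic acid on this bicyclic group also stays open.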